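Chloro next step on the amide aryl of compound 2

The source may hold more compounds than are shown below. What is called first, only, known or untested is meant among the compounds shown, and "the series" means these compounds.

Measured so far:
compound 1 `O=C(Nc1cccc(-n2cc(-c3ccncc3)c(-c3ccc(Cl)c(O)c3)n2)c1)Nc1cccc(C(F)(F)F)c1` — 2020 nM
compound 2 `COc1cc(-c2nn(-c3cccc(NC(=O)c4cccc(C(F)(F)F)c4)c3)cc2-c2ccncc2)ccc1Cl` — 1560 nM

In a functional assay on SK-MEL-2 cells (Homo sapiens) for inhibition, read by sulforhodamine B assay, with a stated time of 48 h (a lower number here means a stronger inhibitor of growth, a higher number a weaker inhibitor of growth), compound 2 gives 1560 nM, the lower of the two numbers, while compound 1 gives 2020 nM; the two values lie within the scatter of each other, so no order between them is claimed.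

Compound 3 `COc1cc(-c2nn(-c3cccc(NC(=O)c4ccc(Cl)c(C(F)(F)F)c4)c3)cc2-c2ccncc2)ccc1Cl` is not yet measured. It differs from compound 2 by chloro in place of hydrogen on an aromatic carbon, the new chloro sitting ortho to the trifluoromethyl group. For the measured compounds named here, no measured pair shows this change, so any step is an expectation only. A small step toward a lower number, or none beyond the scatter, is expected: a 1.6-fold lower number from compound 2 to compound 3 (0.19 log units; within the scatter). Compound 3 is estimated at 1000 nM, range 400 nM to 2500 nM.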

Compound 3, concentration for 50% growth inhibition: 1900 nM
Beside the measured number, compound 3's estimate is 1.9-fold (0.28 log units) below it, and the stated range covers the measured number.
By their numbers in this assay, from the lowest: compounds 2, 3 and 1 (each within the scatter of the next).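

In this assay chloro in place of hydrogen, ortho to a trifluoromethyl group, gives a 1.2-fold higher number from compound 2 to compound 3 (0.09 log units; within the scatter) on going from 3-(trifluoromethyl)phenyl to 4-chloro-3-(trifluoromethyl)phenyl. For the compounds shown here, this is the first measured pair that differs in one place, and at this position the added chloro brings no change that can be told from the scatter.

Going by these compounds, whether an amine, a nitrile or a carboxylic acid at the same position would give a step beyond the scatter remains open. No measurement on hand offers an explanation for this result.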